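Chloro in Place of Nitro on a Shared Core

The compounds below may be only part of what the source reports. "The series", "measured", "known", "first", "only" and "open" are said of these compounds alone.

Measured compounds:
compound 1 `O=[N+]([O-])c1ccc2[nH]c(-c3nc(-c4ccccc4)no3)cc2c1`: > 50000 nM
compound 2 `Clc1ccc2[nH]c(-c3nc(-c4ccccc4)no3)cc2c1`: 29100 nM
compound 3 `O=[N+]([O-])c1ccc2[nH]c(-c3nc(-c4ccc(Cl)cc4)no3)cc2c1`: > 50000 nM

In a functional assay on MCF7 cells (Homo sapiens) for antiproliferative activity, read by WST assay, with a stated time of 72 h (a higher number here means a weaker inhibitor, a lower number a stronger inhibitor), compound 1 gives > 50000 nM, a limit of the assay and not a number. Compound 2 gives 29100 nM. Compound 3 gives > 50000 nM, also a limit. Compound 3 differs from compound 1 by chloro in place of hydrogen on an aromatic carbon, and the values give a step that the two limits leave unreadable from compound 1 to compound 3. The change chloro in place of nitro on an aromatic carbon gave an at least 1.7-fold lower number from compound 1 to compound 2 (0.23 log units; that floor lies within the scatter). Compound 4 `Clc1ccc(-c2noc(-c3cc4cc(Cl)ccc4[nH]3)n2)cc1` carries the same change on the core of compound 3, (chloro in place of nitro on an aromatic carbon), with the place the same in every word. Because the limit of > 50000 nM in this assay, at which 2 of the 3 values shown sit, holds compound 3, and because an at least 1.7-fold lower number from compound 1 to compound 2 (0.23 log units; that floor lies within the scatter) was seen once, the step is expected to be an at least 1.6-fold lower number from compound 3 to compound 4 (0.22 log units; that floor lies within the scatter) in this assay. Compound 4 is estimated at 30000 nM, expected between 12000 nM and 50000 nM.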

Compound 4, half-maximal inhibitory concentration: > 50000 nM
Compound 4: only a limit was reported; the forecaster's own chance of this, stated with the estimate: 35%; middle value at least 1.6-fold (0.22 log units) from the limit.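

In this assay compound 4 gives > 50000 nM, a limit of the assay and not a number. For the compounds shown here, the step from compound 3 to compound 4 and the other steps between two limits cannot be read, so the data neither confirm nor refute that chloro in place of nitro carries from one core to another: the limit of > 50000 nM in this assay, at which 3 of the 4 values shown sit. The one readable new step, for chloro in place of hydrogen on an aromatic carbon, is an at least 1.7-fold higher number from compound 2 to compound 4 (0.23 log units; that floor lies within the scatter), so it shows no firm difference.

The compounds shown leave open how an amine or a carboxylic acid in place of nitro on the shared core would read in this assay. They also leave open whether the compounds at the limit differ from one another at all.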